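The source may hold more compounds than are shown below. What is called first, only, known or untested is meant among the compounds shown, and "the series" means these compounds.

In a functional assay on SK-OV-3 cells (Homo sapiens) for inhibition, read by CCK-8 assay, with a stated time of 70 h (a lower number here means a stronger inhibitor, a higher number a weaker inhibitor), compound 1 (`c1ccc(COc2ccc(OCCOCCNc3cc[nH]c3)cc2)cc1`) gives 11300 nM and compound 2 (`c1ccc(COc2ccc(COc3ccc(OCCOCCNC4CCCCC4)cc3)cc2)cc1`) gives 8080 nM, two values that lie within the usual scatter of each other. Compound 3 (`O=C(O)c1ccccc1COc1ccc(OCCOCCNC2CCCC2)cc1`) gives > 100000 nM, and this is a limit of the assay and not a number. Going by these compounds, it is reported here as the limit of > 100000 nM in this assay, at which 1 of the 3 values shown sits, so the true position of compound 3 remains unknown.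

The next compound, compound 4 (`O=Cc1ccc(COc2ccc(OCCOCCNC3CCCC3)cc2)cc1`), changes one part of compound 3: 4-formylphenyl stands in place of 2-carboxyphenyl on a saturated chain carbon bound to an oxygen on an aromatic ring, (4-formylphenyl in place of 2-carboxyphenyl on a saturated chain carbon bound to an oxygen on an aromatic ring). Within the data shown here, no measured pair in this set differs in only one place, so the size of this step can only be judged loosely. Neither of the two compounds with a numerical result carries the 2-carboxyphenyl group. Compound 1 reads 11300 nM and compound 2 reads 8080 nM, which suggests that compound 4 may also give a number in this assay. The expected change is an at least 5.0-fold lower number from compound 3 to compound 4 (0.69 log units; beyond the scatter), a move toward stronger inhibition that should exceed the scatter. Compound 4 is estimated at 20000 nM, with an expected range of 6000 nM to 70000 nM.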

Compound 4, half-maximal inhibitory concentration: 45000 nM
Compound 4: the middle estimate sits 2.3-fold (0.35 log units) below what was measured, and the stated range covers the measured number.
By their numbers in this assay, from the lowest: compounds 2 and 1 (each within the scatter of the next); then compound 4. At a limit, above all of these: compound 3.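

In this assay, replacing 2-carboxyphenyl with 4-formylphenyl on a saturated chain carbon bound to an oxygen on an aromatic ring brings this core from a limit to a measurable number, with an at least 2.2-fold lower number from compound 3 to compound 4 (0.34 log units; beyond the scatter). Compound 3 stands at a limit and not at a number, so this step gives only the smallest size the change can have: the limit of > 100000 nM in this assay, at which 1 of the 4 values shown sits.

The two groups differ both in their kind and in the number that marks their place on the phenyl ring, so this single step cannot show which of the two differences matters.

The compounds shown leave open how 4-carboxyphenyl or 2-formylphenyl would read at this place, and either one would help separate the kind of group from its place on the phenyl ring. They also leave open how a plain phenyl or a 4-aminophenyl group would read on the core shared by compound 3 and compound 4, which would show whether the formyl group itself is needed for a measurable number.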